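Nitro in place of methoxy: working notes

The compounds below may be only part of what the source reports. "The series", "measured", "known", "first", "only" and "open" are said of these compounds alone.

Among the measured compounds shown here, the series so far gives little to work from. Compound 1 `COc1ccc(-c2c[nH]c(=O)n2-c2cc(OC)c(OC)c(OC)c2)cc1[N+](=O)[O-]` carries a nitro group on the shared core, yet in a functional assay on Bel-7402 cells (Homo sapiens) for cytotoxicity, read by MTT assay, with a stated time of 48 h (on this read-out higher numbers stand for weaker inhibition and lower numbers for stronger inhibition), compound 1 gives "not determined" (no result reported). No reading on a nitro compound is therefore available. Compound 2 `COc1ccc(-c2cn(C(C)=O)c(=O)n2-c2cc(OC)c(OC)c(OC)c2)cc1OC` gives > 50000 nM in this assay, and this is a limit of the assay, not a number. The evidence amounts to the limit of > 50000 nM in this assay, at which 1 of the 2 values shown sits.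

The next compound is compound 3 `COc1ccc(-c2cn(C(C)=O)c(=O)n2-c2cc(OC)c(OC)c(OC)c2)cc1[N+](=O)[O-]`, which is compound 2 with one change: nitro in place of methoxy on an aromatic carbon, ortho to a methoxy group and meta to a large group (nitro in place of methoxy on an aromatic carbon). For the measured compounds named here, with compound 2 at a limit, there is no single number from which to measure a step, and no measured step serves as a guide. Any movement in this assay can only be toward stronger inhibition or stay out of range.

The expected step of an at least 3.3-fold lower number from compound 2 to compound 3 (0.52 log units; beyond the scatter) is a moderate one toward stronger inhibition, and this estimate is loose. For compound 3 the estimated value is 15000 nM, with an expected range from 1000 nM to 60000 nM.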

Compound 3, half-maximal inhibitory concentration: 35700 nM
Compound 3: the middle estimate sits 2.4-fold (0.38 log units) below what was measured; measured number inside the range.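

Nitro on this carbon, ortho to a methoxy group and meta to a large group, brings the first single number to the series: in this assay, compound 3 gives 35700 nM. Nitro in place of methoxy at this position gives an at least 1.4-fold lower number from compound 2 to compound 3 (0.14 log units; that floor lies within the scatter), and the true size of the change remains unknown. The step can be read only as a floor because compound 2 stands at a limit of the assay and not at a number: the limit of > 50000 nM in this assay, at which 1 of the 3 values shown sits.

Going by these compounds, only methoxy and nitro are compared at this position, so it remains open whether the reading tracks the group placed there, and an amine or a carboxylic acid on the same aromatic carbon would test that directly. Also open, on these data alone, is whether the nitro step carries over to other compounds, including those with a longer chain in place of the acetyl group on the shared core.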